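Ester Replacements of a Formyl Group and Cell Tolerance

The compounds below may be only part of what the source reports. "The series", "measured", "known", "first", "only" and "open" are said of these compounds alone.

Compound 1 `O=CCc1c(-c2ccccc2Cl)c2cc(Cl)ccc2[nH]c1=O` carries a formyl group on a saturated chain carbon bound to an aromatic carbon. Among the compounds with values here, in an ADME assay on HepG2 2.2.15 cells (Homo sapiens) for cytotoxicity (a lower number here means that less compound is tolerated, a higher number that more compound is tolerated), compound 1 gives 120000 nM, the highest of the three numbers measured so far. Compound 2 `CC(=O)OCCc1c(-c2ccccc2Cl)c2cc(Cl)ccc2[nH]c1=O` gives 27000 nM in this assay, and compound 3 `O=C(OCCc1c(-c2ccccc2Cl)c2cc(Cl)ccc2[nH]c1=O)C1CCCC1` gives 46000 nM. Both ester replacements move the same way: a 4.4-fold lower number from compound 1 to compound 2 (0.65 log units; beyond the scatter) and a 2.6-fold lower number from compound 1 to compound 3 (0.42 log units; beyond the scatter). Between the two esters, a 1.7-fold higher number from compound 2 to compound 3 (0.23 log units; within the scatter).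

Compound 4 `O=C(OCCc1c(-c2ccccc2Cl)c2cc(Cl)ccc2[nH]c1=O)C1CCCCC1` differs from compound 1 by ((cyclohexylcarbonyl)oxy)methyl in place of formyl on a saturated chain carbon bound to an aromatic carbon. The two ester steps from compound 1 bear on this change, both modest and both giving a lower number, while the exchange of the ring-bearing acyl group for a methyl between compound 2 and compound 3 stayed within the scatter. Compound 4 is therefore expected to land near compound 3. The expected step is a 2.7-fold lower number from compound 1 to compound 4 (0.43 log units; beyond the scatter). For compound 4 the estimate is 45000 nM, with a range from 20000 nM to 100000 nM.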

Compound 4, half-maximal cytotoxic concentration: 38000 nM
The estimate for compound 4 lay 1.2-fold (0.07 log units) above the measured number; the range from low to high includes it.
By their numbers in this assay, from the lowest: compounds 2, 4 and 3 (each within the scatter of the next); then compound 1.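

With cyclohexyl on the acyl group, the ester at this saturated chain carbon again gives a modest drop in this assay, with a 3.2-fold lower number from compound 1 to compound 4 (0.50 log units; beyond the scatter), so all three esters shown lie below the formyl compound. Changing the group on the carbonyl carbon does not separate the esters, as both a 1.2-fold lower number from compound 3 to compound 4 (0.08 log units; within the scatter) and a 1.4-fold higher number from compound 2 to compound 4 (0.15 log units; within the scatter) stay within the scatter, and methyl, cyclopentyl and cyclohexyl therefore cannot be ranked here. No supporting data bear on what lies behind these numbers.

The compounds shown leave open whether an ester is needed for the lower number, since a hydroxyl, an amide or a carboxylic acid on this chain carbon does not appear among them. On these data alone, how an acyl group carrying an amine or a longer chain would stand in this assay also remains open.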